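From Ethyl to 4-Methylphenyl on an Aromatic Nitrogen

The source may report more compounds than this note shows. Statements on the series, on what has been measured and on what is new or still open speak of the compounds shown alone.

In a functional assay on MDA-MB-231 cells (Homo sapiens) for antiproliferative activity, read by MTT assay, with a stated time of 72 h (on this read-out lower numbers stand for stronger inhibition and higher numbers for weaker inhibition), compound 1 `CCn1ccnc1-c1cc(OC)c(OC)c(OC)c1` is recorded only as a limit, > 100000 nM. Compound 4 `COc1cc(-c2nccn2-c2ccc(C)cc2)cc(OC)c1OC` keeps the core of compound 1 and makes one change: 4-methylphenyl in place of ethyl on an aromatic nitrogen, with 4-methylphenyl in place of ethyl on an aromatic nitrogen. Two further compounds, compound 2 `COc1cc(-c2nccn2-c2ccc3[nH]ccc3c2)cc(OC)c1OC` and compound 3 `COc1cc(-c2nccn2-c2ccc3cc[nH]c3c2)cc(OC)c1OC`, also carry an aromatic group on that nitrogen. Given compound 2 at 4300 nM and compound 3 at 7500 nM, a large step toward stronger inhibition is expected in this assay. The estimated change is an at least 16-fold lower number from compound 1 to compound 4 (1.22 log units; beyond the scatter). For compound 4 the expected value is 6000 nM, with an estimated range of 1000 nM to 35000 nM.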

Compound 4, half-maximal inhibitory concentration: 4100 nM
For compound 4 the middle estimate is 1.5-fold (0.17 log units) above the measured one; the range from low to high includes it.
By their numbers in this assay, from the lowest: compounds 4, 2 and 3 (each within the scatter of the next). At a limit, above all of these: compound 1.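

In this assay, going by these compounds alone, 4-methylphenyl in place of ethyl on this aromatic nitrogen gives an at least 24-fold lower number from compound 1 to compound 4 (1.38 log units; beyond the scatter), a single change that the earlier compounds did not isolate. Compound 4 lies within the scatter of compounds 2 and 3, so a six-membered aromatic ring of carbon only, with 0 hydrogen-bond donors, serves on this nitrogen as well as their groups do. Compound 1 is recorded only as a limit, so the full size of the step cannot be read: the limit of > 100000 nM in this assay, at which 1 of the 4 values shown sits.

On these data alone, it remains open whether a longer chain such as butyl on this nitrogen would give a number nearer that of compound 1 or of compound 4. As far as these compounds go, the effect of an amine or a carboxylic acid in place of the methyl on the phenyl ring also remains open.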